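Aryl variation on the shared core

A few compounds are considered here, and "the series" means these few. Any claim that something is new, unique, unknown or untested is made for them only; others in the source may bear on it.

Compound 1 `COc1ccc2cc(C(C)c3nnc4n3N=C(c3ccc(Br)cc3)CS4)ccc2c1` gives 11700 nM in a functional assay on HCT-116 cells (Homo sapiens) for inhibition, read by sulforhodamine B assay, with a stated time of 72 h; a lower number here means a stronger inhibitor, a higher number a weaker inhibitor. Compound 2 `COc1ccc2cc(C(C)c3nnc4n3N=C(c3ccc(Cl)cc3Cl)CS4)ccc2c1` gives 14000 nM in this assay. Going by the values given here, of the two numbers so far, compound 2 holds the higher one, with compound 1 nearest, and the step of a 1.2-fold higher number from compound 1 to compound 2 (0.08 log units; within the scatter) lies within the scatter, so the two compounds cannot be separated on these data. Compound 3 `COc1ccc2cc(C(C)c3nnc4n3N=C(c3ccc(C(F)(F)F)cc3)CS4)ccc2c1` is not yet measured. It differs from compound 2 by 4-(trifluoromethyl)phenyl in place of 2,4-dichlorophenyl on a carbon with a double bond to nitrogen. Among the compounds with values here, the only measured step bearing on this position is the aryl exchange from compound 1 to compound 2, and it produced nothing beyond the scatter. Within the data shown here, with no step yet showing that a change of this aryl group moves the number, the expected step of a 1.1-fold lower number from compound 2 to compound 3 (0.05 log units; within the scatter) in this assay is none beyond the scatter. Compound 3 is therefore estimated at 12500 nM in this assay, with a range from 5000 nM to 30000 nM.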

Compound 3, half-maximal inhibitory concentration: 10800 nM
The estimate for compound 3 lay 1.2-fold (0.06 log units) above the measured number, and the stated range covers the measured number.
By their numbers in this assay, from the lowest: compounds 3, 1 and 2 (each within the scatter of the next).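

In this assay, 4-(trifluoromethyl)phenyl in place of 2,4-dichlorophenyl on the carbon with a double bond to nitrogen (a 1.3-fold lower number from compound 2 to compound 3 (0.11 log units; within the scatter)) and trifluoromethyl in place of bromo on the aromatic carbon (a 1.1-fold lower number from compound 1 to compound 3 (0.03 log units; within the scatter)) both stay within the scatter. With the earlier step, all three pairs among compounds 1, 2 and 3 now lie within the scatter, so this position accepts a third aryl group, and a trifluoromethyl substituent as well as halogens, without a separable change in the number. No measured evidence bears on why the number holds across these groups.

Going by these compounds, whether an amine or a carboxylic acid on this phenyl ring would move the number remains open. No step shown here touches the rest of the shared core, so the contribution of that part also remains open.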